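Fluoro for chloro on the aryl ring of compound 3

The source may hold more compounds than are shown below. What is called first, only, known or untested is meant among the compounds shown, and "the series" means these compounds.

Compound 3 `COc1cc(OC)c(C(=O)/C=C/c2ccc(Cl)cc2)c(OC)c1` carries a 4-chlorophenyl on the double-bonded chain carbon. Among the measured compounds shown here, in a functional assay on Caco-2 cells (Homo sapiens), read by fluorescence and BrdU incorporation, with a stated time of 48 h, tested at 25 uM (a higher number here means a weaker effect of the compound at the concentration tested, a lower number a stronger effect), compound 3 gives 1.5%, the lowest of the three numbers measured so far, though the other two sit within the scatter of it: compound 1 `COc1cc(OC)c(C(=O)/C=C/c2ccccc2SC)c(OC)c1` gives 2.2% and compound 2 `COc1cccc(/C=C/C(=O)c2c(OC)cc(OC)cc2OC)c1` gives 6%, with a number 0.7 percentage points lower from compound 1 to compound 3 (within the scatter) and a number 4.5 percentage points lower from compound 2 to compound 3 (within the scatter). No order among the three is claimed.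

Compound 4 `COc1cc(OC)c(C(=O)/C=C/c2ccc(F)cc2)c(OC)c1` differs from compound 3 in one place: fluoro in place of chloro on an aromatic carbon. Cut one bond further out, the change reads 4-chlorophenyl to 4-fluorophenyl, the new group sitting para to a large group. For the measured compounds named here, none of the measured steps exchanges one halogen for another on that ring; the three steps available, a number 3.8 percentage points higher from compound 1 to compound 2 (within the scatter), a number 0.7 percentage points lower from compound 1 to compound 3 (within the scatter) and a number 4.5 percentage points lower from compound 2 to compound 3 (within the scatter), each swap the whole aryl group and all stay within the scatter. A single-atom exchange is a smaller change than any of these, so the step from compound 3 to compound 4 is expected to stay within the scatter as well, estimated as a number 1.5 percentage points higher from compound 3 to compound 4 (within the scatter). For compound 4 the expected value in this assay is 3%, with a range from 0% to 11%.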

Compound 4, a percentage reported as activity, at one concentration (the size of the read-out at that concentration, not a potency): 13%
Compound 4: middle estimate off by 10 percentage points, on the low side; the whole stated range lies below it.
By their numbers in this assay, from the lowest: compounds 3, 1, 2 and 4 (each within the scatter of the next, the first and the last beyond it).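

In this assay, among the compounds shown here, the aromatic carbon para to a large group proves sensitive to a single-atom exchange: fluoro in place of chloro gives a number 11.5 percentage points higher from compound 3 to compound 4 (beyond the scatter), a step that the whole-aryl swaps among the earlier compounds, all within the scatter, did not produce. The effect of the compound at the concentration tested is therefore weaker with 4-fluorophenyl than with 4-chlorophenyl, and the other steps place compound 4 unevenly: a number 10.8 percentage points higher from compound 1 to compound 4 (beyond the scatter) also separates it from the compound with 2-(methylsulfanyl)phenyl, whereas a number 7 percentage points higher from compound 2 to compound 4 (within the scatter) leaves it unseparated from the compound with 3-methoxyphenyl. Nothing available explains why these two halogens differ at this carbon.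

From the compounds shown here alone, whether bromo, an amine or a carboxylic acid on the same aromatic carbon would read like chloro or like fluoro remains open, as does the reading of the plain phenyl with no group there. With one concentration in one cell assay, the compounds shown also leave open whether the halogen step would persist at other concentrations.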